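Chlorobenzyl Amine in Place of a Branched Alkyl Chain

This account rests on a few compounds, and the source may have more. Where it says the series, first, only, none or still open, it means among the compounds named here.

Measured compounds:
compound 1, `CCOC(=O)c1cnc(NC2CC2)n2nc(-c3ccco3)nc12`: 2260 nM
compound 2, `CCCCC(CC)CNc1ncc(C(=O)O)c2nc(-c3ccco3)nn12`: > 10000 nM

In a functional assay on CHO cells for antagonist activity at adenosine receptor A2b (Homo sapiens) (on this read-out lower numbers stand for stronger inhibition and higher numbers for weaker inhibition), compound 1 gives 2260 nM. Compound 2 has the free acid on the shared core and a branched alkyl chain on the ring nitrogen; in this assay compound 2 reaches only the limit of the assay, > 10000 nM, so no number is known for it. That limit is described as the limit of > 10000 nM in this assay, at which 1 of the 2 values shown sits. Compound 3, `O=C(O)c1cnc(NCc2ccc(Cl)cc2)n2nc(-c3ccco3)nc12`, keeps the acid and the furan of compound 2 and differs only at the amine substituent: 4-chlorophenyl in place of 1-ethylpentyl on a saturated chain carbon bound to a nitrogen on an aromatic ring. Among the measured compounds shown here, no step between two measured compounds is available to calibrate this change. The expectation for compound 3 rests on compound 1 reaching a measurable value with a smaller amine substituent, and an aromatic ring in the entering group is estimated to move the step from compound 2 to compound 3 toward stronger inhibition, beyond the usual scatter, as an at least 3.3-fold lower number from compound 2 to compound 3 (0.52 log units; beyond the scatter). For compound 3 the estimated inhibition constant in this assay is 3000 nM, expected to fall between 500 nM and 20000 nM, though a second limit result cannot be excluded.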

Compound 3, inhibition constant: > 30000 nM
Compound 3 was reported as a limit; the forecaster's own chance of this, stated with the estimate: 30%; at least 10-fold (1.00 log units) between middle value and limit.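

In this assay, compound 2 and compound 3 were both reported only as limits, so the step between them cannot be read. The limit for compound 2 is > 10000 nM. The limit for compound 3 is > 30000 nM. The compounds shown leave open how 4-chlorobenzyl and 2-ethylhexyl compare on the acid, as neither has a measured number.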